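Chloro in place of methoxy: cytotoxicity on Vero cells

This account rests on a few compounds, and the source may have more. Where it says the series, first, only, none or still open, it means among the compounds named here.

Compound 1 `O=C1CSC(c2ccc([N+](=O)[O-])cc2)N1CCN1CCCCC1`: 100%
Compound 2 `COc1ccccc1C1SCC(=O)N1CCN1CCCCC1`: 100%
Compound 3 `COc1cccc(C2SCC(=O)N2CCN2CCCCC2)c1`: 100%

Of the compounds shown here, three sharing one core have been measured in an ADME assay on Vero cells (Chlorocebus sabaeus) for cytotoxicity, read by neutral red uptake, tested at 12.3 ug/mL; a higher number here means a weaker effect of the compound at the concentration tested, a lower number a stronger effect. Compound 1 gives 100% there. Compound 2 gives 100% in this assay, and compound 3 gives 100%. On these numbers compound 2 stands level with compound 1 and with compound 3, the differences lying within the scatter of the measurement, so no order among the three can be read from the values shown.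

The account now follows the step from compound 2 to compound 4 `O=C1CSC(c2ccccc2Cl)N1CCN1CCCCC1`, which has not yet been measured in this assay. The structural change is chloro in place of methoxy on an aromatic carbon. Among the measured compounds shown here, no step between measured compounds that differ in only one place is available to calibrate this change. Given that compound 1 and compound 3 both match compound 2 in this assay, the expected step of no change at the digits printed from compound 2 to compound 4 (within the scatter) is none beyond the scatter. Compound 4 is therefore expected to give 100%, within a range from 85% to 100%.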

Compound 4, a percentage reported as activity, at one concentration (the size of the read-out at that concentration, not a potency): 100%
For compound 4 middle estimate and measured number coincide at the digits printed, within the range that was stated.
By their numbers in this assay, from the lowest: compounds 1, 2, 3 and 4 (each within the scatter of the next).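

In this assay, chloro in place of methoxy on an aromatic carbon, ortho to a large group, gives no change at the digits printed from compound 2 to compound 4 (within the scatter), and this is the first step shown that can be read across a single change. Compound 1, compound 2 and compound 3 stood level, but no two of them differed in one place; this pair shows that methoxy can give way to chloro here, one heavy atom replacing two and the hydrogen-bond acceptor lost, with the read-out unmoved at the concentration tested. No measurement shown bears on the reason for this outcome.

Going by these compounds, whether this tolerance extends to other groups remains open, for instance an amine or a carboxylic acid on the same aromatic carbon. The compounds shown also leave open what a longer chain at this place would do, and whether any change to the shared core would lower the read-out at all.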